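The source may hold more compounds than are shown below. What is called first, only, known or untested is meant among the compounds shown, and "the series" means these compounds.

Working notes on the series.

Compound 1 `COc1cc(C)cc(-c2c(-c3ccnc(-c4ccc(C(C)=O)cc4)c3)cnn2CC#N)c1` sits at the weak end of what has been measured: in a functional assay on HCT-15 cells (Homo sapiens) for inhibition, read by sulforhodamine B assay, with a stated time of 48 h (a higher number here means a weaker inhibitor of growth, a lower number a stronger inhibitor of growth), compound 1 gives 3140 nM, the highest of the two numbers in hand. For the measured compounds named here, the only other measured member, compound 2 `COc1cc(C)cc(-c2nn(CC#N)cc2-c2ccnc(-c3ccc(N(C)C)cc3)c2)c1`, gives 350 nM in this assay, a number well beyond the scatter below compound 1. Going by the values given here, compound 2 already carries a dimethylamino group on its outer phenyl ring, but it differs from compound 1 in more than one place, so no single-change step between the two can be read off; their two values simply show that the dimethylamino-bearing member is the stronger inhibitor of growth here.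

Compound 3 `COc1cc(C)cc(-c2c(-c3ccnc(-c4ccc(N(C)C)cc4)c3)cnn2CC#N)c1` is the direct single-change partner of compound 1: dimethylamino in place of acetyl on an aromatic carbon, which the two structures also express as 4-acetylphenyl to 4-(dimethylamino)phenyl. Among the compounds with values here, no measured step of this exact kind exists in the set. Within the data shown here, the expectation is nonetheless a lowering of the number beyond the scatter, by about a 6.3-fold lower number from compound 1 to compound 3 (0.80 log units; beyond the scatter), because compound 2 gives 350 nM as the only dimethylamino-bearing member. Compound 3 is therefore estimated at 500 nM, with a range from 150 nM to 1600 nM.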

Compound 3, concentration for 50% growth inhibition: 76.6 nM
The estimate for compound 3 lay 6.5-fold (0.81 log units) above the measured number; measured number outside the range, below it.
By their numbers in this assay, from the lowest: compound 3; then compound 2; then compound 1.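

With the rest of compound 1 held constant, replacing acetyl with dimethylamino on this aromatic carbon gives, in this assay, a 41-fold lower number from compound 1 to compound 3 (1.61 log units; beyond the scatter), so the effect of this change can now be read on its own, which the earlier pair did not allow. The two groups have the same heavy-atom count and the same hydrogen-bond donor and acceptor counts, so these counts do not separate them; the listed differences are the carbonyl oxygen and double bond of acetyl and the nitrogen of dimethylamino. Nothing in hand explains the size of this step.

From the compounds shown here alone, with only acetyl and dimethylamino compared at this position, it remains open whether the large step is specific to dimethylamino or would also appear with a primary amine, a methoxy group or a morpholine ring in the same place. Going by these compounds, it also remains open whether the same change would give a step of similar size on the core of compound 2, or with dimethylamino elsewhere on the ring.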